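The source may hold more compounds than are shown below. What is called first, only, known or untested is meant among the compounds shown, and "the series" means these compounds.

Compound 1 `CNc1nc(NCc2ccc(C(=O)Nc3ccc(F)cc3)cc2)c2ccccc2n1` gives 2900 nM in a functional assay on HCT-116 cells (Homo sapiens) for inhibition, read by luminescence and resazurin assay, with a stated time of 3 days (on this read-out lower numbers stand for stronger inhibition and higher numbers for weaker inhibition), which places it second highest of the three numbers in hand. Compound 2 `O=C(Nc1ccc(F)cc1)c1ccc(CNc2nc(NC3CC3)nc3ccccc23)cc1` gives 2700 nM in this assay, and the step of a 1.1-fold lower number from compound 1 to compound 2 (0.03 log units; within the scatter) is too small to read as a change. Compound 3 `C=CCNc1nc(NCc2ccc(C(=O)Nc3ccc(F)cc3)cc2)c2ccccc2n1` gives 14000 nM in this assay; the steps of a 4.8-fold higher number from compound 1 to compound 3 (0.68 log units; beyond the scatter) and a 5.2-fold higher number from compound 2 to compound 3 (0.71 log units; beyond the scatter) are the only ones that clear the scatter. All three measured steps alter the group on a nitrogen of the shared core and leave the amide end of the molecule untouched.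

Compound 4 `CNc1nc(NCc2ccc(NC(=O)c3ccncc3)cc2)c2ccccc2n1` differs from compound 1 in exactly that untouched end: ((pyridin-4-yl)carbonyl)amino in place of (4-fluorophenyl)carbamoyl on an aromatic carbon. For the measured compounds named here, none of the measured steps bears on this change, so the measured series gives no anchor for its size or direction, and the expectation rests on the change being at least as large as those already seen. Compound 4 is therefore expected to give roughly 5000 nM in this assay, with a wide range from 1000 nM to 25000 nM. The expected step is a 1.7-fold higher number from compound 1 to compound 4 (0.24 log units; within the scatter).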

Compound 4, half-maximal inhibitory concentration: > 20000 nM
Compound 4 ended at the assay's limit; the forecaster's own chance of this, stated with the estimate: 10%; middle value at least 4.0-fold (0.60 log units) from the limit.
By their numbers in this assay, from the lowest: compounds 2 and 1 (each within the scatter of the next); then compound 3. At a limit, above all of these: compound 4.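

For the compounds shown here, the amide end of the molecule, untouched in the earlier steps, proves not to be a silent place: swapping (4-fluorophenyl)carbamoyl for ((pyridin-4-yl)carbonyl)amino on this aromatic carbon, para to a large group, gives an at least 6.8-fold higher number from compound 1 to compound 4 (0.83 log units; beyond the scatter). Until now, only the group on a nitrogen of the shared core had moved the number beyond the scatter, and only in the allyl compound, compound 3. In this assay compound 4 gives > 20000 nM, which is a limit and not a number: the limit of > 20000 nM in this assay, at which 1 of the 4 values shown sits.

The swap replaces the ring and turns the amide around in a single step, so the compounds shown cannot say which of the two carries the loss. A ((4-fluorophenyl)carbonyl)amino group or a (pyridin-4-yl)carbamoyl group on the same carbon would separate them.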